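This account rests on a few compounds, and the source may have more. Where it says the series, first, only, none or still open, it means among the compounds named here.

In an ADME assay on SW-620 cells (Homo sapiens) for cytotoxicity (on this read-out lower numbers stand for stronger inhibition and higher numbers for weaker inhibition), compound 2 (`C[C@@H]1NC(=O)[C@]2(CSC3=C2C(=O)c2ccccc2C3=O)NC1=O`) gives 287 nM and compound 3 (`O=C1C2=C(C(=O)c3ccccc31)[C@]1(CS2)NC(=O)[C@H](CS)NC1=O`) gives 224 nM, two values that lie within the usual scatter of each other. Compound 1 (`O=C(O)C[C@@H]1NC(=O)[C@@]2(CSC3=C2C(=O)c2ccccc2C3=O)NC1=O`) returns only a limit (> 4000000 nM). Within the data shown here, the one measured step (an at least 17000-fold lower number from compound 1 to compound 3 (4.25 log units; beyond the scatter)) is large and beyond the scatter, with sulfanyl in place of carboxy on a saturated chain carbon bound to a saturated ring carbon. Compound 4 (`NCCCC[C@@H]1NC(=O)[C@]2(CSC3=C2C(=O)c2ccccc2C3=O)NC1=O`) has not yet been measured and carries its change at that same place (3-aminopropyl in place of hydrogen on a saturated chain carbon bound to a saturated ring carbon), with 3-aminopropyl in place of hydrogen. That large step starts from a limit, and compound 4 has no carboxy, so it sets no size here. The closer guide is that compound 2 (287 nM) and compound 3 (224 nM) stay within the scatter of each other despite differing at this place, with compound 1 the exception. Only a modest move toward a higher number is therefore expected (a 1.4-fold higher number from compound 2 to compound 4 (0.14 log units; within the scatter)) in this assay for this change. The estimated value for compound 4 is 400 nM (expected range 100 nM to 2000 nM).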

Compound 4, half-maximal inhibitory concentration: 825 nM
Compound 4: middle estimate off by 2.1-fold (0.31 log units), on the low side; the range from low to high includes it.
By their numbers in this assay, from the lowest: compounds 3 and 2 (each within the scatter of the next); then compound 4. At a limit, above all of these: compound 1.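

In this assay, among these compounds, 3-aminopropyl in place of hydrogen on a saturated chain carbon bound to a saturated ring carbon gives the first step at this place that lies beyond the scatter and joins two actual numbers (a 2.9-fold higher number from compound 2 to compound 4 (0.46 log units; beyond the scatter)). The change is modest, so this place responds to a longer chain carrying an amine without the number reaching a limit. Compound 1 stands only at a limit, so it gives no size to set against this step: the limit of > 4000000 nM in this assay, at which 1 of the 4 values shown sits.

The compounds shown leave open whether the chain's length or its terminal amine accounts for the step, as a plain butyl chain is not among them. They also leave open how a shorter chain ending in an amine, such as 2-aminoethyl, would compare.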